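The compounds below may be only part of what the source reports. "The series", "measured", "known", "first", "only" and "open" are said of these compounds alone.

Working notes on the hydrazone series. Compound 1 `Cc1cc(Cl)ccc1Nc1nc(C(F)(F)F)ccc1C(=O)N/N=C/c1ccc([N+](=O)[O-])cc1` gives in a functional assay on NCI60 cells (Homo sapiens) for cytotoxicity, read by sulforhodamine B assay, with a stated time of 48 h (on this read-out higher numbers stand for weaker inhibition of growth and lower numbers for stronger inhibition of growth), a value of 4680 nM. Compound 2 `Cc1ccc(Cl)cc1Nc1nc(C(F)(F)F)ccc1C(=O)N/N=C/c1ccc(Cl)cc1` gives 5250 nM in this assay. Compound 3 `COc1ccc(Cl)cc1Nc1nc(C(F)(F)F)ccc1C(=O)N/N=C/c1ccc([N+](=O)[O-])cc1` gives 8710 nM in this assay. Compound 3 thus carries the highest of the three numbers, but its gaps to compound 2 and to compound 1 both lie within the scatter, so nothing separates the three. Among the measured compounds shown here, the one single-point step available, a 1.9-fold higher number from compound 1 to compound 3 (0.27 log units; within the scatter), concerns the aryl group on the ring nitrogen and not the imine end.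

Compound 4 `COc1ccc(Cl)cc1Nc1nc(C(F)(F)F)ccc1C(=O)N/N=C/c1cc(OC)c(OC)c(OC)c1` differs from compound 3 in one place: 3,4,5-trimethoxyphenyl in place of 4-nitrophenyl on a carbon with a double bond to nitrogen. For the measured compounds named here, no measured pair isolates a change at this position; compound 1 and compound 2 differ at the imine aryl but also at the aryl on the nitrogen, so what their two values show cannot be assigned to either change. Going by the values given here, with no direct precedent and with every step so far within the scatter, the step from compound 3 to compound 4 is expected to be small, a 1.0-fold lower number from compound 3 to compound 4 (0.01 log units; within the scatter), with no direction favoured. Compound 4 is therefore estimated at 8500 nM in this assay, within a range of 3000 nM to 25000 nM.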

Compound 4, concentration for total growth inhibition: 10500 nM
The estimate for compound 4 lay 1.2-fold (0.09 log units) below the measured number, and the stated range covers the measured number.
By their numbers in this assay, from the lowest: compounds 1, 2, 3 and 4 (each within the scatter of the next, the first and the last beyond it).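

The imine aryl now has its first isolated step: in this assay, 3,4,5-trimethoxyphenyl in place of 4-nitrophenyl on a carbon with a double bond to nitrogen gives a 1.2-fold higher number from compound 3 to compound 4 (0.08 log units; within the scatter). The earlier compounds shown here could not show this, as compound 1 and compound 2 differ in two places, whereas here a single exchange of 9 heavy atoms for 12 heavy atoms, with the loss of the double bond outside aromatic rings, leaves the read-out within the scatter. No measured data are available to explain this result.

From the compounds shown here alone, this single step was read only with 5-chloro-2-methoxyphenyl on the nitrogen, so whether the same exchange stays within the scatter with 4-chloro-2-methylphenyl there remains open. Both imine groups seen in this pair are substituted phenyl rings, which leaves open whether a carboxylic acid or a dimethylamino group on that ring, or a saturated cyclohexyl ring in place of the phenyl, would move the number beyond the scatter.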